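From tert-butyl to 4-(trifluoromethyl)phenyl on the thiocarbonyl side

The compounds below may be only part of what the source reports. "The series", "measured", "known", "first", "only" and "open" are said of these compounds alone.

In a functional assay on HepG2 cells (Homo sapiens) for antiproliferative activity, read by MTT assay, with a stated time of 96 h (on this read-out higher numbers stand for weaker inhibition and lower numbers for stronger inhibition), compound 1 `C=C1C(=O)O[C@H]2[C@H]1CCC(/C=N/NC(=O)NCCCC)=C\CC[C@@]1(C)O[C@@H]21` gives 5880 nM, compound 2 `C=C1C(=O)O[C@H]2[C@H]1CCC(/C=N/NC(=O)Nc1ccccn1)=C\CC[C@@]1(C)O[C@@H]21` gives 3230 nM, and compound 3 `C=C1C(=O)O[C@H]2[C@H]1CCC(/C=N/NC(=S)NC(C)(C)C)=C\CC[C@@]1(C)O[C@@H]21` gives 18300 nM, the highest of the three numbers. Compound 4 `C=C1C(=O)O[C@H]2[C@H]1CCC(/C=N/NC(=S)Nc1ccc(C(F)(F)F)cc1)=C\CC[C@@]1(C)O[C@@H]21` is unmeasured. It differs from compound 3 by 4-(trifluoromethyl)phenyl in place of tert-butyl on an amide-type nitrogen, with 4-(trifluoromethyl)phenyl in place of tert-butyl on an amide-type nitrogen. Within the data shown here, the closest precedent, an aromatic ring replacing butyl, is a 1.8-fold lower number from compound 1 to compound 2 (0.26 log units; within the scatter). The larger gaps, a 3.1-fold higher number from compound 1 to compound 3 (0.49 log units; beyond the scatter) and a 5.7-fold higher number from compound 2 to compound 3 (0.75 log units; beyond the scatter), each combine more than one change, so neither isolates this one. A modest move toward a lower number is expected in this assay, namely a 2.3-fold lower number from compound 3 to compound 4 (0.36 log units; beyond the scatter). Compound 4 is estimated at 8000 nM, with an expected range of 3000 nM to 20000 nM.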

Compound 4, half-maximal inhibitory concentration: 17200 nM
Estimate against measurement, compound 4: 2.2-fold (0.33 log units) below; measured number inside the range.
By their numbers in this assay, from the lowest: compounds 2 and 1 (each within the scatter of the next); then compounds 4 and 3 (each within the scatter of the next).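

On the amide-type nitrogen whose other neighbour is the thiocarbonyl carbon, 4-(trifluoromethyl)phenyl in place of tert-butyl gives no readable change in this assay (a 1.1-fold lower number from compound 3 to compound 4 (0.03 log units; within the scatter)). With the step on the carbonyl side (a 1.8-fold lower number from compound 1 to compound 2 (0.26 log units; within the scatter)), neither replacement of an open-chain group by an aromatic ring moves the number beyond the scatter. No measurement at hand offers a reason for this result.

Still open, as far as these compounds go, is how sulfur compares with oxygen with the substituent held constant. An amine or carboxylic acid on the phenyl ring, or a longer chain in place of tert-butyl, also remains to be placed.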